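The source may report more compounds than this note shows. Statements on the series, on what has been measured and on what is new or still open speak of the compounds shown alone.

Measured so far:
compound 1, `c1ccc(C2CCCCN2C2CCN(CCCc3c[nH]c4ccc(-n5cnnc5)cc34)CC2)cc1`, 4.7 nM
compound 2, `c1cc(CNC2CCN(CCCc3c[nH]c4ccc(-n5cnnc5)cc34)CC2)co1`, 7.1 nM

Both compounds were tested in an assay on CHO cells for agonist activity at 5-hydroxytryptamine receptor 1D (Homo sapiens), read by GTPgammaS binding; a lower number here means that less compound is needed, a higher number that more compound is needed for the effect. Compound 1 gives 4.7 nM there, and compound 2 gives 7.1 nM; the two numbers lie within the usual scatter of each other, so on the evidence so far neither can be set apart from the other, and compound 2 stands level with compound 1.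

Compound 3, `C[C@@H](NC1CCN(CCCc2c[nH]c3ccc(-n4cnnc4)cc23)CC1)c1ccccc1`, has not yet been measured. It differs from compound 2 in one place: 1-phenylethyl in place of (furan-3-yl)methyl on an amine nitrogen. For the measured compounds named here, no measured pair shows this exact exchange, so the size of the step can only be guessed. Since compound 1 and compound 2 already carry rather different groups on the same side of the shared core yet give matching numbers, the expectation for compound 3 is a step of a 1.4-fold lower number from compound 2 to compound 3 (0.15 log units; within the scatter), which is no more than the scatter. The value expected for compound 3 in this assay is 5 nM, with a range from 1.5 nM to 16 nM.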

Compound 3, half-maximal effective concentration: 13 nM
The estimate for compound 3 lay 2.6-fold (0.41 log units) below the measured number; the range from low to high includes it.
By their numbers in this assay, from the lowest: compounds 1, 2 and 3 (each within the scatter of the next, the first and the last beyond it).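

In this assay, putting 1-phenylethyl in place of (furan-3-yl)methyl on an amine nitrogen gives a 1.8-fold higher number from compound 2 to compound 3 (0.26 log units; within the scatter), so on this amine nitrogen the six-membered aromatic ring of carbon only, with its defined stereocentre, stands level with the five-membered aromatic ring that holds an oxygen. The hydrogen-bond acceptor counted in the group that leaves is therefore not required to keep the number within the scatter of compound 2. Nothing available accounts for the size of this step.

Going by these compounds, whether the defined stereocentre of compound 3 matters stays open, since the opposite stereoisomer of the 1-phenylethyl group would be needed to tell. A plain benzyl group on the same amine nitrogen would separate the change of ring from the added methyl, and an isopropyl group would show whether an aromatic ring is needed there at all.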